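The compounds below may be only part of what the source reports. "The series", "measured", "known", "first", "only" and "open" are said of these compounds alone.

Measured so far in a functional assay on HCT-116 cells (Homo sapiens) for inhibition, read by CCK-8 assay, with a stated time of 48 h; on this read-out lower numbers stand for stronger inhibition and higher numbers for weaker inhibition:
Compound 1 `COc1cc(-c2ccnc3cc(-c4ccc(Cl)cc4)nn23)cc(OC)c1OC`: 3340 nM
Compound 2 `COc1cc(-c2ccnc3cc(-c4ccc(-c5cnn(C)c5)cc4)nn23)cc(OC)c1OC`: 2110 nM

Only these two compounds have been measured, and their numbers cannot be ranked. Among the compounds with values here, the one measured step, a 1.6-fold lower number from compound 1 to compound 2 (0.20 log units; within the scatter), stays within the usual scatter, so compound 2 at 2110 nM stands level with compound 1.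

Within the data shown here, the unmeasured compound 3 `COc1cc(-c2ccnc3cc(-c4ccc(C(C)(C)C)cc4)nn23)cc(OC)c1OC` keeps the shared core of compound 2 and alters only one group: tert-butyl in place of 1-methyl-1H-pyrazol-4-yl on an aromatic carbon. The new tert-butyl sits on the same aromatic carbon, where compound 1 carries chloro and compound 2 carries 1-methyl-1H-pyrazol-4-yl. Among the measured compounds shown here, the sole evidence for this place is the step of a 1.6-fold lower number from compound 1 to compound 2 (0.20 log units; within the scatter), a single exchange that did not move the number beyond the scatter. On that thin basis, no step beyond the scatter is expected in this assay, and neither direction can be firmly expected. The estimate amounts to an expected 1.2-fold higher number from compound 2 to compound 3 (0.09 log units; within the scatter). For compound 3 the expected value is 2600 nM, with an estimated range of 1100 nM to 6200 nM.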

Compound 3, half-maximal inhibitory concentration: > 10000 nM
Compound 3: a limit, no number; the forecaster's own chance of this, stated with the estimate: 5%; middle value at least 3.8-fold (0.58 log units) away from the limit.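

In this assay the result for compound 3 is a limit and not a number: the limit of > 10000 nM in this assay, at which 1 of the 3 values shown sits.

The exchange of chloro for 1-methyl-1H-pyrazol-4-yl had not moved the number beyond the scatter, but this aromatic carbon, para to a large group, is now seen not to be indifferent to what it carries. Placing tert-butyl there gives an at least 4.7-fold higher number from compound 2 to compound 3 (0.67 log units; beyond the scatter), and against the chloro group it gives an at least 2.9-fold higher number from compound 1 to compound 3 (0.47 log units; beyond the scatter), so both steps point to weaker inhibition, each of a size that is itself bounded by the limit. Within the data shown here, the three compounds show that the change matters but not which feature of tert-butyl is responsible, since its departure from the other two groups is seen only in this single case.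

As far as these compounds go, it remains open how far compound 3 actually lies past its limit, and so how large the two steps truly are. From the compounds shown here alone, it is also open whether a methoxy group, an amine or a carboxylic acid on this same aromatic carbon would stay level with compound 1 and compound 2 or would fall away as tert-butyl does.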